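Adding one fluoro to compound 2

This account rests on a few compounds, and the source may have more. Where it says the series, first, only, none or still open, it means among the compounds named here.

- compound 1 `C=C[C@@H]1C[C@@H](Cc2ccc(OC)c(O)c2)[C@H]2C(=O)C=CC(=C)[C@H]21` gives 1.17 nM
- compound 2 `C=C1C=CC(=O)[C@@H]2[C@H](Cc3ccc(OCOC)cc3)CC[C@H]12` gives 63.6 nM

In a functional assay on MCF7 cells (Homo sapiens) for antiproliferative activity, with a stated time of 72 h (on this read-out higher numbers stand for weaker inhibition and lower numbers for stronger inhibition), compound 2 gives 63.6 nM and so holds the higher of the two numbers. That makes it the weaker inhibitor of the pair, by a gap well beyond the scatter of repeated measurements. Among the compounds with values here, the only other measured compound, compound 1, reads 1.17 nM and differs from compound 2 in more than one place, so the gap cannot be pinned on any single change.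

Compound 3 (`C=C1C=CC(=O)[C@@H]2[C@H](Cc3ccc(OCOC)c(F)c3)CC[C@H]12`) is compound 2 with one small edit (fluoro in place of hydrogen on an aromatic carbon): fluoro in place of hydrogen on an aromatic carbon, ortho to a methoxymethoxy group. Within the data shown here, no measured pair here shows what such a swap does, so the data give no direction for it. With so small an edit, the expectation is no shift beyond the scatter, leaving the number close to that of compound 2 (63.6 nM). The expected size of the change is small (a 1.2-fold lower number from compound 2 to compound 3 (0.06 log units; within the scatter)). For compound 3 the estimated value is 55 nM (expected range from 18 nM to 170 nM).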

Compound 3, half-maximal inhibitory concentration: 77.2 nM
Compound 3: middle estimate off by 1.4-fold (0.15 log units), on the low side; low and high end bracket the measured number.
By their numbers in this assay, from the lowest: compound 1; then compounds 2 and 3 (each within the scatter of the next).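

In this assay, placing fluoro instead of hydrogen on this aromatic carbon, ortho to a methoxymethoxy group, gives a 1.2-fold higher number from compound 2 to compound 3 (0.08 log units; within the scatter) and so produces no shift that can be told apart from the ordinary spread of repeat measurements. Within the data shown here, this is the first step that changes a single place, so it gives a direct reading for this position that the earlier compounds could not: on the framework of compound 2, hydrogen and fluoro at this carbon read alike in these cells. No supporting measurement bears on why the number holds steady.

A single small atom at a single position leaves open how this carbon would respond to a larger group, such as a methoxy group, a nitrile or an amine, any of which might move the number further than fluoro does. From the compounds shown here alone, it also remains open whether the same swap would be as quiet on compound 1 , which gives 1.17 nM in this assay and carries a differently substituted aromatic ring.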